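The source may hold more compounds than are shown below. What is called first, only, known or untested is meant among the compounds shown, and "the series" means these compounds.

Compound 1 `c1ccc2c(c1)CC(CCCN1CCN(c3cccc4c3OCCO4)CC1)C2`: 40 mg/kg. Compound 2 `C1=C(CCN2CCN(c3cccc4c3OCCO4)CC2)c2ccccc2C1`: > 2.5 mg/kg. Compound 3 `c1ccc2c(c1)CC2CN1CCN(c2cccc3c2OCCCO3)CC1`: > 10 mg/kg.

These three compounds were tested in a functional assay on the whole organism for agonist activity, with Rattus norvegicus as the target; on this read-out lower numbers stand for an effect already at smaller amounts and higher numbers for an effect only at larger amounts of compound. Compound 1 gives a number, 40 mg/kg. For compound 2 the result is a limit of the assay and not a number, (the limit of > 2.5 mg/kg in this assay, at which 1 of the 3 values shown sits). For compound 3 the result is likewise a limit, (the limit of > 10 mg/kg in this assay, at which 1 of the 3 values shown sits). Compound 2 thus stands at a limit, with one further limit beside it and a single numeric value in the whole set. Compound 4 `Clc1cccc2c1CC2CCN1CCN(c2cccc3c2OCCO3)CC1` differs from compound 2 in one place: a group of 9 heavy atoms (8 carbon, 1 chlorine; one four-membered non-aromatic ring of carbon only, one six-membered aromatic ring of carbon only) in place of a group of 9 heavy atoms (9 carbon; one five-membered non-aromatic ring of carbon only, one six-membered aromatic ring of carbon only), on a saturated chain carbon, two bonds along the chain from an amine nitrogen in a ring. Within the data shown here, no two measured compounds differ in one place, so no measured step guides this change, and the direction is open. I expect for compound 4 a step that the limit leaves unreadable from compound 2 to compound 4, which may again end at a limit. For compound 4 I estimate 20 mg/kg, within 5 mg/kg to 80 mg/kg.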

Compound 4, minimum effective dose: 40 mg/kg
Estimate against measurement, compound 4: 2.0-fold (0.30 log units) below; low and high end bracket the measured number.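

No size can be read for the change from compound 2 to compound 4, because compound 2 stands at a limit of the assay: the limit of > 2.5 mg/kg in this assay, at which 1 of the 4 values shown sits.

The compounds shown leave open whether this exchange of groups shifts the dose needed, and in which direction.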